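Replacing the hydrazone ester arm with a chloro-nitrile arm

The compounds below may be only part of what the source reports. "The series", "measured", "known", "first", "only" and "open" are said of these compounds alone.

Compound 2, `CCOC(=O)C(=NNC1=C(C(=O)OCC)C(c2ccc(N(C)C)cc2)c2c(C)n[nH]c2N1)C(=O)OCC`, has been examined in a functional assay on HepG2 cells (Homo sapiens) for inhibition, read by MTT assay, with a stated time of 48 h (a lower number here means a stronger inhibitor, a higher number a weaker inhibitor), where compound 2 gives 80800 nM. Among the compounds with values here, its only measured neighbour is compound 1, `CCOC(=O)C1=C(N/N=C(\C#N)C(N)=O)Nc2[nH]nc(C)c2C1c1ccc(N(C)C)cc1`, which in this assay gives 48400 nM; the two numbers lie within the scatter of each other. Within the data shown here, the one measured step, a 1.7-fold higher number from compound 1 to compound 2 (0.22 log units; within the scatter), exchanged one group on an amine nitrogen for another and did not move the number beyond the scatter.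

The unmeasured compound 3, `CCOC(=O)C1=C(N/N=C(/Cl)C#N)Nc2[nH]nc(C)c2C1c1ccc(N(C)C)cc1`, is reached from compound 2 by the change (a group of 5 heavy atoms (2 carbon, 2 nitrogen, 1 chlorine; no ring) in place of a group of 12 heavy atoms (7 carbon, 1 nitrogen, 4 oxygen; no ring), on an amine nitrogen). Among the measured compounds shown here, this is a second exchange at the same amine nitrogen, and the only comparable step, from compound 1 to compound 2, stayed within the scatter, so no step beyond the scatter is expected in this assay for compound 3 either. Because the step of a 1.7-fold higher number from compound 1 to compound 2 (0.22 log units; within the scatter) gave no clear direction, compound 3 is estimated to sit close to both measured compounds, at 50000 nM, with a range from 18000 nM to 140000 nM, which is the expected step of a 1.6-fold lower number from compound 2 to compound 3 (0.21 log units; within the scatter).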

Compound 3, half-maximal inhibitory concentration: 23600 nM
Estimate against measurement, compound 3: 2.1-fold (0.33 log units) above; the measured number falls inside the stated range.
By their numbers in this assay, from the lowest: compound 3; then compounds 1 and 2 (each within the scatter of the next).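

In this assay, this amine nitrogen, whose other neighbours are a double-bonded ring carbon, now gives a step beyond the scatter, which the earlier exchange there did not: the group of 5 heavy atoms replacing the group of 12 heavy atoms gives (a 3.4-fold lower number from compound 2 to compound 3 (0.53 log units; beyond the scatter)). The comparison with compound 1 narrows the change, since compound 1 and compound 3 share the nitrile and the core and differ only in chloro in place of carbamoyl on a carbon with a double bond to nitrogen (a 2.1-fold lower number from compound 1 to compound 3 (0.31 log units; beyond the scatter)). Compound 3 is therefore the strongest inhibitor of the three, by modest steps, while compound 1 and compound 2 stay within the scatter of each other, and nothing at hand explains why the chloro compound stands apart.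

From the compounds shown here alone, it remains open whether this gain belongs to chloro itself or would also appear with bromo, fluoro, methyl or an amine on that carbon. Going by these compounds, it is equally open whether the nitrile contributes, and whether the same order would hold with the ethyl ester of the core replaced by a carboxylic acid or an amide.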